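Series notes: 2,4-difluorophenyl entering the shared core

The source may hold more compounds than are shown below. What is called first, only, known or untested is meant among the compounds shown, and "the series" means these compounds.

In an assay on CHO cells for displacement of a labelled ligand from adenosine receptor A3 (Homo sapiens), read by scintillation counting, tested at 10 uM (on this read-out higher numbers stand for more inhibition at the one concentration tested (going by the name of the read-out) and lower numbers for less inhibition), compound 1 `Cc1csc(N)c1C(=O)c1ccc(Cl)cc1` gives 1%, compound 2 `CC(C)(C)c1csc(N)c1C(=O)c1ccc(Cl)cc1` gives 1% and compound 3 `CC(C)(C)Cc1csc(N)c1C(=O)c1ccc(Cl)cc1` gives 5%. Compound 3 holds the highest of the three numbers, yet both other compounds lie within the scatter of it: a number 4 percentage points higher from compound 1 to compound 3 (within the scatter) and a number 4 percentage points higher from compound 2 to compound 3 (within the scatter), as does no change at the digits printed from compound 1 to compound 2 (within the scatter). Compound 4 `CC(C)(C)Cc1c(-c2ccc(F)cc2F)sc(N)c1C(=O)c1ccc(Cl)cc1` differs from compound 3 by 2,4-difluorophenyl in place of hydrogen on an aromatic carbon. For the measured compounds named here, no measured step touches this position or brings in an aromatic ring; the measured steps concern only the methyl, tert-butyl and neopentyl groups and were all flat. The series therefore gives no guidance on this change, and in this assay no step beyond the scatter is expected, the estimated step being a number 3 percentage points higher from compound 3 to compound 4 (within the scatter). Compound 4 is expected to give 8%, within a range of -5% to 30%.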

Compound 4, a percentage reported as inhibition, at one concentration (the size of the read-out at that concentration, not a potency): 1%
Compound 4: middle estimate off by 7 percentage points, on the high side, within the range that was stated.
By their numbers in this assay, from the lowest: compounds 1, 2, 4 and 3 (each within the scatter of the next).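

In this assay the aromatic carbon next to the ring sulfur takes 2,4-difluorophenyl with a number 4 percentage points lower from compound 3 to compound 4 (within the scatter). An aromatic ring at this position therefore leaves the read-out as flat as the methyl, tert-butyl and neopentyl changes did. No evidence at hand bears on the reason for this result. As far as these compounds go, it remains open whether an amine or a carboxylic acid at this position would give a step beyond the scatter. Also open, from the compounds shown here alone, is whether 2,4-difluorophenyl would read the same with methyl in place of neopentyl.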